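Bromo for trifluoromethyl on the sulfonyl-bearing phenyl of compound 2

The source may report more compounds than this note shows. Statements on the series, on what has been measured and on what is new or still open speak of the compounds shown alone.

Compound 1 `O=C1/C(=C/c2ccncc2)CN(S(=O)(=O)c2ccccc2)C/C1=C\c1ccccc1F`: 8400 nM
Compound 2 `O=C1/C(=C/c2ccncc2)CN(S(=O)(=O)c2ccc(C(F)(F)F)cc2)C/C1=C\c1ccccc1F`: 9500 nM

Both compounds were tested in a functional assay on QGY-7703 cells (Homo sapiens) for cytotoxicity, read by MTT assay, with a stated time of 24 h; on this read-out lower numbers stand for stronger inhibition and higher numbers for weaker inhibition. Among the measured compounds shown here, compound 2 gives 9500 nM, and compound 1, the only other measured compound, lies within the scatter of it. For the measured compounds named here, the single step available, a 1.1-fold higher number from compound 1 to compound 2 (0.05 log units; within the scatter), shows that replacing a hydrogen on that aromatic carbon with trifluoromethyl left the number unchanged beyond the scatter. Compound 3 `O=C1/C(=C/c2ccncc2)CN(S(=O)(=O)c2ccc(Br)cc2)C/C1=C\c1ccccc1F` differs from compound 2 by bromo in place of trifluoromethyl on an aromatic carbon. Going by the values given here, since the only comparable step, a 1.1-fold higher number from compound 1 to compound 2 (0.05 log units; within the scatter), was flat, no shift beyond the scatter is expected, so compound 3 is estimated at 9000 nM, between 4500 nM and 18000 nM, meaning an expected step of a 1.1-fold lower number from compound 2 to compound 3 (0.02 log units; within the scatter).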

Compound 3, half-maximal inhibitory concentration: 11500 nM
Compound 3: middle estimate off by 1.3-fold (0.11 log units), on the low side, within the range that was stated.
By their numbers in this assay, from the lowest: compounds 1, 2 and 3 (each within the scatter of the next).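

In this assay, bromo in place of trifluoromethyl gives a 1.2-fold higher number from compound 2 to compound 3 (0.08 log units; within the scatter), and the same group compared with hydrogen gives a 1.4-fold higher number from compound 1 to compound 3 (0.14 log units; within the scatter), so neither step leaves the scatter. Hydrogen, trifluoromethyl and bromo at this position therefore cannot be told apart by this read-out, even though bromo has one heavy atom and trifluoromethyl has four.

As far as these compounds go, whether a different kind of group here, such as an amine or a carboxylic acid, would move the number beyond the scatter stays open. Nothing given here explains why these three compounds read alike.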